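Working notes: isopropoxy for bromo, compound 3 to compound 4

This account rests on a few compounds, and the source may have more. Where it says the series, first, only, none or still open, it means among the compounds named here.

Measured so far:
compound 1 `COCCOc1ccc2c(c1)OC(COc1ccc(CCC(=O)O)c(F)c1)CC2`: 2370 nM
compound 2 `CC#C[C@@H](CC(=O)O)c1ccc(OC[C@H]2COc3ccccc3O2)cc1`: 90 nM
compound 3 `CC#C[C@@H](CC(=O)O)c1ccc(OC[C@H]2COc3ccc(Br)cc3O2)cc1`: 210 nM

In a functional assay on HEK293 cells for agonist activity at Free fatty acid receptor 1 (Homo sapiens), read by fluorescence and calcium flux, with a stated time of 10 min (on this read-out higher numbers stand for an effect only at larger amounts of compound and lower numbers for an effect already at smaller amounts), compound 3 gives 210 nM, the second highest of the three numbers. Within the data shown here, its nearest neighbour is compound 2, and that step, a 2.3-fold higher number from compound 2 to compound 3 (0.37 log units; beyond the scatter), is the only single-point change measured in the set. Among the measured compounds shown here, compound 1, on a different core, lies furthest away with 2370 nM; no single step connects it to compound 3.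

Compound 4 `CC#C[C@@H](CC(=O)O)c1ccc(OC[C@H]2COc3ccc(OC(C)C)cc3O2)cc1` differs from compound 3 by isopropoxy in place of bromo on an aromatic carbon. For the measured compounds named here, no measured step replaces bromo by an alkoxy group at this position, so the only guidance is that a change at this carbon, from hydrogen to bromo, moved the number only modestly, as a 2.3-fold higher number from compound 2 to compound 3 (0.37 log units; beyond the scatter) shows. A similar modest outcome, in either direction, is the working assumption, and no shift beyond the scatter is firmly expected.

For compound 4 the expected step is a 1.1-fold lower number from compound 3 to compound 4 (0.02 log units; within the scatter). Compound 4 is therefore estimated at 200 nM, with a range of 70 nM to 600 nM.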

Compound 4, half-maximal effective concentration: 280 nM
Compound 4: the middle estimate sits 1.4-fold (0.15 log units) below what was measured; the measured number falls inside the stated range.
By their numbers in this assay, from the lowest: compound 2; then compounds 3 and 4 (each within the scatter of the next); then compound 1.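

Isopropoxy and bromo on this aromatic carbon cannot be told apart in this assay (a 1.3-fold higher number from compound 3 to compound 4 (0.12 log units; within the scatter)), even though the entering group has 4 heavy atoms, including an oxygen, where the leaving group has 1. Set against hydrogen, isopropoxy gives a step beyond the scatter (a 3.1-fold higher number from compound 2 to compound 4 (0.49 log units; beyond the scatter)), so compound 2 keeps the lowest number of the three compounds on the shared core, with both substituted compounds above it. No measurement is available to explain these steps.

Going by these compounds, whether the hydrogen level can be matched or bettered by another group at this carbon, such as fluoro, methoxy, an amine or a carboxylic acid, stays open. Also open, on these data alone, is whether a longer chain such as n-butoxy would stay level with isopropoxy or move the number further from compound 2.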